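The source may report more compounds than this note shows. Statements on the series, on what has been measured and on what is new or still open speak of the compounds shown alone.

Measured so far:
- compound 1 `CC(C)=CCC/C(C)=C/CC/C(C)=C/CSc1ccccc1C(=O)OC(C)C`: 70000 nM
- compound 2 `CC(C)=CCC/C(C)=C/CC/C(C)=C/CSc1ccccc1C(=O)OCc1ccccc1`: 95000 nM

In a functional assay on PANC-1 cells (Homo sapiens) for cytotoxicity, with a stated time of 7 days (on this read-out higher numbers stand for weaker inhibition and lower numbers for stronger inhibition), compound 2 gives 95000 nM, within the scatter of compound 1. Compound 3 `CC(C)=CCC/C(C)=C/CC/C(C)=C/CSc1ccccc1C(N)=O` arises through (amino in place of benzyloxy on a carbonyl carbon), amino in place of benzyloxy on a carbonyl carbon. Among the compounds with values here, the only measured guide is a 1.4-fold higher number from compound 1 to compound 2 (0.13 log units; within the scatter). Within the data shown here, that step, benzyl in place of isopropyl, keeps the oxygen, and no measured compound carries amino, so the guide is weak. A moderate move toward stronger inhibition is expected, tentatively, as a 2.4-fold lower number from compound 2 to compound 3 (0.38 log units; beyond the scatter). For compound 3 the estimated value is 40000 nM, with an expected range of 12000 nM to 100000 nM.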

Compound 3, half-maximal inhibitory concentration: 20000 nM
Compound 3: middle estimate off by 2.0-fold (0.30 log units), on the high side, within the range that was stated.
By their numbers in this assay, from the lowest: compound 3; then compounds 1 and 2 (each within the scatter of the next).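

In this assay, within the data shown here, amino on the carbonyl carbon gives the first change beyond the scatter at this position, with a 4.8-fold lower number from compound 2 to compound 3 (0.68 log units; beyond the scatter) and a 3.5-fold lower number from compound 1 to compound 3 (0.54 log units; beyond the scatter). Benzyloxy and isopropoxy had stayed within the scatter of each other, so this position does respond, but only to a change of the group as a whole rather than between these two oxygen-linked groups. Nothing available explains the size or direction of this step. The compounds shown leave open how methylamino, dimethylamino or a carboxylic acid would read on the same carbonyl carbon. They also leave open whether the gain from amino would persist with a shorter chain on the shared core.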